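This account rests on a few compounds, and the source may have more. Where it says the series, first, only, none or still open, it means among the compounds named here.

Series notes. Compound 1 `c1csc(-c2ccccc2OCC2=NCCN2)c1`, compound 2 `c1ccc(-c2ccsc2)c(OCC2=NCCN2)c1` and compound 3 `Cc1ccoc1-c1ccccc1OCC1=NCCN1` share one core and differ only in the five-membered ring on the aromatic carbon. In a functional assay for activation of Alpha-1A adrenergic receptor (Homo sapiens), read by calcium flux (on this read-out higher numbers stand for an effect only at larger amounts of compound and lower numbers for an effect already at smaller amounts), compound 1 gives 1 nM, compound 2 gives 0.251 nM and compound 3 gives 3.16 nM, the highest of the three; the steps of a 3.2-fold higher number from compound 1 to compound 3 (0.50 log units; beyond the scatter) and a 13-fold higher number from compound 2 to compound 3 (1.10 log units; beyond the scatter) place it beyond the scatter from both. Compound 4 `Cc1cnsc1-c1ccccc1OCC1=NCCN1` carries the change (4-methyl-1,2-thiazol-5-yl in place of 3-methylfuran-2-yl on an aromatic carbon). Among the compounds with values here, no measured step covers this ring; the two measured steps show thiophen-2-yl and thiophen-3-yl giving lower numbers than 3-methylfuran-2-yl. For compound 4 the expected step is a 1.8-fold lower number from compound 3 to compound 4 (0.24 log units; within the scatter), toward a lower number, modest at most. Compound 4 is estimated at 1.8 nM in this assay, with a range of 0.5 nM to 6 nM.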

Compound 4, half-maximal effective concentration: 12.6 nM
Estimate against measurement, compound 4: 7.0-fold (0.85 log units) below, and the stated range ends below it.
By their numbers in this assay, from the lowest: compound 2; then compound 1; then compound 3; then compound 4.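

In this assay the ring with two hetero atoms, 4-methyl-1,2-thiazol-5-yl, stands highest of the four on this aromatic carbon, with a 4.0-fold higher number from compound 3 to compound 4 (0.60 log units; beyond the scatter) and a 13-fold higher number from compound 1 to compound 4 (1.10 log units; beyond the scatter) and a 50-fold higher number from compound 2 to compound 4 (1.70 log units; beyond the scatter) all beyond the scatter. Exchanging the hetero atoms of a methyl-bearing five-membered ring thus moves the number upward, even with the heavy-atom count unchanged. No data at hand bear on the reason for this.

Whether the ring nitrogen or the ring sulfur accounts for the shift stays open, and 3-methylthiophen-2-yl would bear on that. As far as these compounds go, the effect of a phenyl ring or an amine-bearing ring at this place is also open.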